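The compounds below may be only part of what the source reports. "The series", "measured", "known", "first", "only" and "open" are said of these compounds alone.

Of the compounds shown here, three have been tested in a functional assay on Bel-7402 cells (Homo sapiens) for cytotoxicity, read by resazurin assay, with a stated time of 72 h; on this read-out higher numbers stand for weaker inhibition and lower numbers for stronger inhibition. Compound 1 `N#CCCSC(=S)NCc1cccnc1` gives 1030 nM in this assay, the lowest of the three numbers. Compound 3 `Cc1cc(CNC(=S)SCCC#N)n(C)n1` gives 4260 nM, and compound 2 `Cc1c(CNC(=S)SCCC#N)cnn1-c1ccccc1` gives 24900 nM; both numbers stand beyond the scatter above that of compound 1, so compound 1 is the strongest inhibitor of the three. The three compounds share the same chain and keep the same nitrile at its end; they differ only in the aromatic ring that carries the chain.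

Compound 4 `NC(=O)CCSC(=S)NCc1cccnc1` has not yet been measured. It differs from compound 1 in one place only: carbamoyl in place of cyano on a saturated chain carbon, two bonds along the chain from a sulfur. Going by the values given here, no measured pair shows this exact change, so the size of the step can only be guessed from the change itself, which swaps one small group for another of similar size. The expected step is a 1.9-fold higher number from compound 1 to compound 4 (0.29 log units; within the scatter), a small move toward weaker inhibition, close to the edge of the scatter. Compound 4 is therefore expected to give 2000 nM in this assay, within a range from 700 nM to 6000 nM.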

Compound 4, half-maximal inhibitory concentration: 3330 nM
Compound 4: middle estimate off by 1.7-fold (0.22 log units), on the low side; measured number inside the range.
By their numbers in this assay, from the lowest: compound 1; then compounds 4 and 3 (each within the scatter of the next); then compound 2.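

Until now every compound kept its nitrile, so nothing showed how this position responds to a change of group. In this assay, carbamoyl in place of cyano on a saturated chain carbon, two bonds along the chain from a sulfur, gives a 3.2-fold higher number from compound 1 to compound 4 (0.51 log units; beyond the scatter), a modest step beyond the scatter toward weaker inhibition, so the nitrile can be exchanged here for a group that adds a hydrogen-bond donor and inhibition persists, though it is weaker. No measurement at hand gives a reason for the size of this step.

Going by these compounds, how a carboxylic acid or an amine in this place would compare remains open. So does whether the same change would give a step of similar size on the core of compound 3.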